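Taking the chloro group off compound 2

The source may report more compounds than this note shows. Statements on the series, on what has been measured and on what is new or still open speak of the compounds shown alone.

Among the measured compounds shown here, in a functional assay on MCF7 cells (Homo sapiens) for antiproliferative activity, read by MTT assay, with a stated time of 72 h (a higher number here means a weaker inhibitor, a lower number a stronger inhibitor), compound 2 `CCOc1ccc(-c2ncnn2-c2cc(OC)c(OC)c(OC)c2)cc1Cl` gives 17 nM and is the only compound with an actual number so far. Compound 1 `COc1cc(-n2ncnc2-c2ccc(Cl)cc2)cc(OC)c1OC` is reported only as the limit > 10000 nM and not as a number. Compound 3 `CCOc1ccc(-c2ncnn2-c2cc(OC)c(OC)c(OC)c2)cc1` has hydrogen in place of chloro on an aromatic carbon, ortho to an ethoxy group hydrogen in place of chloro on an aromatic carbon and is otherwise unchanged. For the measured compounds named here, no measured step shows what this swap does, so the expectation starts from compound 2 at 17 nM and allows for a modest loss in this assay or none beyond the scatter. The expected change is a 2.4-fold higher number from compound 2 to compound 3 (0.37 log units; beyond the scatter) and stays small. For compound 3 the estimated value is 40 nM within an expected range from 5 nM to 400 nM in this measurement.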

Compound 3, half-maximal inhibitory concentration: 50 nM
The estimate for compound 3 lay 1.3-fold (0.10 log units) below the measured number; the range from low to high includes it.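

In this assay, the chloro group ortho to an ethoxy group adds only a modest amount: hydrogen in its place gives a 2.9-fold higher number from compound 2 to compound 3 (0.47 log units; beyond the scatter). The ethoxy group matters far more, since ethoxy in place of chloro on an aromatic carbon gives an at least 200-fold lower number from compound 1 to compound 3 (2.30 log units; beyond the scatter). Compound 1 stands only at a limit of the assay, so that step is a bound and not an exact size: the limit of > 10000 nM in this assay, at which 1 of the 3 values shown sits.

The compounds shown leave open whether a longer chain such as propoxy, or an amine, could take the place of the ethoxy group. They also leave open how fluoro or methyl would compare with chloro at this position.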